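Swapping Methyl for Chloro at the Edge of Detection

The source may hold more compounds than are shown below. What is called first, only, known or untested is meant among the compounds shown, and "the series" means these compounds.

Compound 1, `O=C1OCC[C@@H]1NC(=S)SCCOc1ccccc1`: 63800 nM
Compound 2, `Cc1cc(Cl)ccc1NCC(=O)N[C@H]1CCOC1=O`: > 64000 nM

Of the compounds shown here, two have been tested in a functional assay on DU-145 cells (Homo sapiens) for antiproliferative activity, read by MTT assay, with a stated time of 72 h; on this read-out lower numbers stand for stronger inhibition and higher numbers for weaker inhibition. Compound 1 gives 63800 nM, a weak result. For compound 2 the assay reports only a limit, > 64000 nM, which is not a number but the boundary of what the test resolves. Compound 2 therefore stands at the weaker end of what has been seen so far: the limit of > 64000 nM in this assay, at which 1 of the 2 values shown sits.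

Compound 3 `O=C(CNc1ccc(Cl)cc1Cl)N[C@H]1CCOC1=O` has not yet been measured. It differs from compound 2 in one place: chloro in place of methyl on an aromatic carbon. Among the measured compounds shown here, no pair of measured compounds shares this kind of change, so there is nothing to show how large a shift such a swap produces in this assay. Because compound 2 sits at the limit > 64000 nM, a further weakening could not even be registered, and a change within the usual scatter would leave compound 3 near the same boundary. The step from compound 2 to compound 3 is expected to be small: a step that the limit leaves unreadable from compound 2 to compound 3. Compound 3 is estimated at 70000 nM, with a range from 20000 nM to 250000 nM, and it is expected that the assay will most likely again report only a limit.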

Compound 3, half-maximal inhibitory concentration: > 64000 nM
Compound 3: a limit, no number (the forecaster's own chance of this, stated with the estimate: 65%); the middle value is on the limit's open side.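

Compound 3 gives > 64000 nM in this assay, which is a limit and not a number. Among the compounds shown here, compound 2 also stands at a limit, so no step from compound 2 to compound 3 can be read. The compounds shown leave open how far chloro in place of methyl on an aromatic carbon moves activity, because the values gather at one boundary: the limit of > 64000 nM in this assay, at which 2 of the 3 values shown sit.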